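Swapping the side-chain group on a stomach-active compound

A few compounds are considered here, and "the series" means these few. Any claim that something is new, unique, unknown or untested is made for them only; others in the source may bear on it.

- compound 1 `COC(=O)CC/C=C\CC[C@H]1C(=O)C[C@@H](O)[C@@H]1/C=C/CC(C)(O)CCC1CCCC1`: 0.00009 mg/kg
- compound 2 `COC(=O)CC/C=C\CC[C@H]1C(=O)C[C@@H](O)[C@@H]1/C=C/C[C@@](C)(O)C#CC1=CCCC1`: 0.0028 mg/kg

In a functional assay on the whole organism (stomach) with Canis familiaris (Canis lupus familiaris) as the target (a lower number here means that less compound is needed, a higher number that more compound is needed for the effect), compound 2 has the higher of the two numbers, 0.0028 mg/kg, so more of it is needed for the effect. Compound 3 `COC(=O)CC/C=C\CC[C@H]1C(=O)C[C@@H](O)[C@@H]1/C=C/CC(C)(O)CCC1CCC1` is the next to be tested. Its difference from compound 2 is this: 3-cyclobutyl-1-hydroxy-1-methylpropyl in place of 3-(cyclopent-1-en-1-yl)-1-hydroxy-1-methylprop-2-yn-1-yl on a saturated chain carbon bound to a double-bonded chain carbon. Among the compounds with values here, the only measured step that bears on this is a 31-fold higher number from compound 1 to compound 2 (1.49 log units; beyond the scatter), which is large and put the 3-(cyclopent-1-en-1-yl)-1-hydroxy-1-methylprop-2-yn-1-yl group in place of 3-cyclopentyl-1-hydroxy-1-methylpropyl. Within the data shown here, compound 3 drops that same group for a similar saturated one, but with a smaller ring, whose effect no measured compound shows. A large step towards a lower number is therefore expected, somewhat smaller than the measured one. The expected change is a 14-fold lower number from compound 2 to compound 3 (1.15 log units; beyond the scatter). For compound 3 the estimated value is 0.0002 mg/kg, with an expected range of 0.00004 mg/kg to 0.001 mg/kg.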

Compound 3, dose for half-maximal effect: 0.00009 mg/kg
Compound 3: the middle estimate sits 2.2-fold (0.35 log units) above what was measured; low and high end bracket the measured number.
By their numbers in this assay, from the lowest: compounds 1 and 3 (each within the scatter of the next); then compound 2.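

In this assay, the saturated 3-cyclobutyl-1-hydroxy-1-methylpropyl group in place of the 3-(cyclopent-1-en-1-yl)-1-hydroxy-1-methylprop-2-yn-1-yl group gives a 31-fold lower number from compound 2 to compound 3 (1.49 log units; beyond the scatter), the same size of step as the one seen earlier, in the opposite direction. Cyclobutyl in place of cyclopentyl gives no change at the digits printed from compound 1 to compound 3 (within the scatter), so this position accepts either ring size on the saturated chain without a detectable difference in this measurement. No supporting evidence is available to explain either result.

The compounds shown leave open whether the triple bond, the ring double bond or the defined stereocentre accounts for the higher number of compound 2, since these differences arrive together. They also leave open how a cyclohexyl or phenyl ring, or a longer chain, would behave here.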